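Working notes: from compound 2 to compound 3

The source may report more compounds than this note shows. Statements on the series, on what has been measured and on what is new or still open speak of the compounds shown alone.

In a functional assay on A-375 cells (Homo sapiens) for activation, with a stated time of 3 days (a lower number here means that less compound is needed, a higher number that more compound is needed for the effect), compound 1 `O=C(Nc1ccc(-c2cscn2)cc1)C1CCN(Cc2ccc(F)c(F)c2)CC1` gives 19000 nM and compound 2 `O=C(Nc1ccc(-c2cscn2)cc1)C1CCCN(Cc2ccccc2F)C1` gives 7000 nM, the lower of the two numbers, with a gap beyond the usual scatter. Compound 3 `O=C(Nc1ccc(-c2cscn2)cc1)C1CCCN(Cc2cccc(C(F)(F)F)c2)C1` carries 3-(trifluoromethyl)phenyl in place of 2-fluorophenyl on a saturated chain carbon bound to an amine nitrogen in a ring. Within the data shown here, no measured step in this assay covers this change, so no shift beyond the scatter is expected, with a slight lean towards a lower number. The expected step is a 1.3-fold lower number from compound 2 to compound 3 (0.10 log units; within the scatter). For compound 3 the estimated value is 5500 nM, with an expected range of 2000 nM to 15000 nM.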

Compound 3, half-maximal effective concentration: > 20000 nM
Compound 3 was reported as a limit; the forecaster's own chance of this, stated with the estimate: 10%; middle value at least 3.6-fold (0.56 log units) from the limit.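

In this assay, replacing 2-fluorophenyl with 3-(trifluoromethyl)phenyl on a saturated chain carbon bound to an amine nitrogen in a ring gives the only single-place step shown, and it lies beyond the scatter: an at least 2.8-fold higher number from compound 2 to compound 3 (0.45 log units; beyond the scatter). This position therefore responds to the group it carries, and the entering group, with 10 heavy atoms against 7, gives no gain. Compound 3 stands at a limit of the assay: the limit of > 20000 nM in this assay, at which 1 of the 3 values shown sits.

On these data alone, it remains open whether the step follows the trifluoromethyl group itself or its place on the phenyl ring. As far as these compounds go, how an amine or a carboxylic acid on that ring would read also remains open.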